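The source may hold more compounds than are shown below. What is called first, only, known or untested is meant among the compounds shown, and "the series" means these compounds.

Compound 1 `NC(=O)c1c(NC(=O)c2ccccc2Cl)sc2c1CCN(Cc1ccc(Cl)cc1Cl)C2` and compound 2 `NC(=O)c1c(NC(=O)c2ccccc2F)sc2c1CCN(Cc1ccc(Cl)cc1Cl)C2` share one core and differ in a single spot: fluoro in place of chloro on an aromatic carbon. In a functional assay on MKN-74 cells (Homo sapiens) for antiproliferative activity, with a stated time of 24 h (a higher number here means a weaker inhibitor, a lower number a stronger inhibitor), compound 1 gives 16300 nM, while compound 2 gives 9610 nM, so the swap made a 1.7-fold lower number from compound 1 to compound 2 (0.23 log units; within the scatter). Compound 3 `NC(=O)c1c(NC(=O)c2ccccc2Cl)sc2c1CCN(C(=S)Nc1cc(C(F)(F)F)cc(C(F)(F)F)c1)C2` keeps the chloro group of compound 1 on a different core; how the two cores differ is not broken down here. In this assay compound 3 gives 15000 nM. Compound 4 `NC(=O)c1c(NC(=O)c2ccccc2F)sc2c1CCN(C(=S)Nc1cc(C(F)(F)F)cc(C(F)(F)F)c1)C2` has not yet been measured; it differs from compound 3 by fluoro in place of chloro on an aromatic carbon, the same change at the same place as between compound 1 and compound 2. Because a 1.7-fold lower number from compound 1 to compound 2 (0.23 log units; within the scatter) stayed within the usual scatter, the step to compound 4 is expected to be a 1.6-fold lower number from compound 3 to compound 4 (0.20 log units; within the scatter). Compound 4 is therefore estimated at 9500 nM, likely between 4500 nM and 20000 nM.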

Compound 4, half-maximal inhibitory concentration: 13300 nM
Compound 4: middle estimate off by 1.4-fold (0.15 log units), on the low side, and the stated range covers the measured number.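

In this assay, putting fluoro in place of chloro on an aromatic carbon gives a 1.1-fold lower number from compound 3 to compound 4 (0.05 log units; within the scatter). Set beside the earlier step, the swap reads alike on the two cores: the same change on two cores in this assay, a 1.7-fold lower number (0.23 log units; within the scatter) from compound 1 to compound 2 and a 1.1-fold lower number (0.05 log units; within the scatter) from compound 3 to compound 4, 1.5-fold (0.18 log units) apart, within the scatter of two such steps. Neither step stands clear of the scatter, so this agreement is only between two small steps and does not show that the swap itself changes activity, or how a change with a clear effect would carry from one core to the other.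

Only chloro and fluoro appear at this spot on the benzoyl ring. As far as these compounds go, whether a larger or different group there, such as methoxy, an amine or a nitrile, would move the number on either core remains open.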